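Chalcone growth inhibitors: methoxy versus trifluoromethyl on the aryl ketone

The compounds below may be only part of what the source reports. "The series", "measured", "known", "first", "only" and "open" are said of these compounds alone.

Measured compounds:
- compound 1 `COc1cccc(C(=O)/C=C/c2ccccc2)c1`: 14800 nM
- compound 2 `O=C(/C=C/c1ccccc1)c1cccc(C(F)(F)F)c1`: > 20000 nM
- compound 3 `O=C(/C=C/c1ccccc1)c1ccccc1C(F)(F)F`: 8500 nM

In an ADME assay on MSTO-211H cells (Homo sapiens) for inhibition, read by trypan blue exclusion, with a stated time of 72 h (a lower number here means a stronger inhibitor of growth, a higher number a weaker inhibitor of growth), compound 1 gives 14800 nM. For compound 2 the value in this assay is a limit of the assay, > 20000 nM (the limit of > 20000 nM in this assay, at which 1 of the 3 values shown sits). Compound 3 gives 8500 nM in this assay, the lowest of the two numbers, with compound 1 the nearest and within the scatter.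

One change connects compound 2 and compound 1: methoxy in place of trifluoromethyl on an aromatic carbon. It made a step of an at least 1.3-fold lower number from compound 2 to compound 1 (0.13 log units; that floor lies within the scatter), a floor that lies within the scatter.

Compound 3 and compound 2 have the same atoms joined differently; the difference between their two cores is not broken down here.

Compound 4 `COc1ccccc1C(=O)/C=C/c1ccccc1` is not yet measured. It differs from compound 3 by the same kind of change: methoxy in place of trifluoromethyl on an aromatic carbon. The place is not the same as before, since in compound 1 the methoxy stands meta to a large group, whereas in compound 4 it stands ortho to a large group.

Beside the earlier step, the expected step is a 1.2-fold lower number from compound 3 to compound 4 (0.08 log units; within the scatter), resting on compound 3 at 8500 nM and on the earlier change giving only a step within the scatter. Compound 4 is therefore expected to give about 7000 nM, between 2500 nM and 20000 nM.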

Compound 4, concentration for 50% growth inhibition: 9500 nM
Estimate against measurement, compound 4: 1.4-fold (0.13 log units) below; the measured number falls inside the stated range.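

In this assay, methoxy in place of trifluoromethyl on an aromatic carbon, ortho to a large group, makes a step of a 1.1-fold higher number from compound 3 to compound 4 (0.05 log units; within the scatter), so on this core the change does not stand out from the scatter. The same change can now be read on two cores: the same change on two cores in this assay, an at least 1.3-fold lower number (0.13 log units; that floor lies within the scatter) from compound 2 to compound 1 and a 1.1-fold higher number (0.05 log units; within the scatter) from compound 3 to compound 4; the limit leaves it open whether they differ

For the compounds shown here, compound 2 gives > 20000 nM, which is a limit of the assay, so this comparison does not show whether the change carries the same size from one core to the other; it shows only that the step on the core of compound 3 is small.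

The compounds shown leave open whether the number would also hold steady with other groups in the same place, such as an amine, a carboxylic acid or a longer chain. They also leave open how the change would read on a further core where both partners give a number and neither gives a limit.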